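Isobutyl in place of 4-bromophenyl: expected cytotoxicity of compound 4

This account rests on a few compounds, and the source may have more. Where it says the series, first, only, none or still open, it means among the compounds named here.

Three analogues share one core and differ only in the group on the saturated chain carbon bound to an aromatic nitrogen. Compound 1 `Fc1cccc(F)c1Cn1ccc2nc(-c3ccccc3)nc-2c1` reaches the limit of the assay in an ADME assay on MDBK cells (Bos taurus) for cytotoxicity (a higher number here means that more compound is tolerated, a lower number that less compound is tolerated), giving > 100000 nM. Compound 2 `COc1cccc(Cn2ccc3nc(-c4ccccc4)nc-3c2)c1` likewise gives only the limit > 100000 nM. Among the measured compounds shown here, compound 3 `Brc1ccc(Cn2ccc3nc(-c4ccccc4)nc-3c2)cc1` gives 83000 nM in this assay, the single numerical value among the three. Both measured steps that reach a number, an at least 1.2-fold lower number from compound 1 to compound 3 (0.08 log units; that floor lies within the scatter) and an at least 1.2-fold lower number from compound 2 to compound 3 (0.08 log units; that floor lies within the scatter), are floored by a limit and lie within the scatter; the step that the two limits leave unreadable from compound 1 to compound 2 is unreadable because of the limit of > 100000 nM in this assay, at which 2 of the 3 values shown sit.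

Compound 4 `CC(C)CCn1ccc2nc(-c3ccccc3)nc-2c1` carries the change (isobutyl in place of 4-bromophenyl on a saturated chain carbon bound to an aromatic nitrogen). For the measured compounds named here, no measured step exchanges an aromatic ring for a chain, so the measured steps bear only indirectly on it. Going by the values given here, as every value so far sits at or near the limit, compound 4 is estimated to give 100000 nM, with a range from 50000 nM to 200000 nM. This corresponds to an expected 1.2-fold higher number from compound 3 to compound 4 (0.08 log units; within the scatter), a step not beyond the scatter, with a fair chance that only a limit is reported.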

Compound 4, half-maximal cytotoxic concentration: > 100000 nM
Compound 4 ended at the assay's limit; the forecaster's own chance of this, stated with the estimate: 55%; the middle value lies on the limit itself.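

In this assay, compound 4 gives > 100000 nM, which is a limit and not a number. Among the compounds shown here, the one readable step is an at least 1.2-fold higher number from compound 3 to compound 4 (0.08 log units; that floor lies within the scatter) and, with isobutyl in place of 4-bromophenyl, extends the series to a group with no ring, without any shift beyond the scatter. The steps to compound 4 from compound 1 and compound 2 cannot be read because both values in each pair are limits: the limit of > 100000 nM in this assay, at which 3 of the 4 values shown sit.

Going by these compounds, how 2,6-difluorophenyl, 3-methoxyphenyl and isobutyl rank at this position stays open, as does the true size of the step to compound 4. Also open, on these data alone, is whether an amine or a carboxylic acid on the saturated chain carbon bound to an aromatic nitrogen would give a readable number in this assay.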